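Nitrooxy for bromo and furanyl for methoxyphenyl in chalcone amides

This account rests on a few compounds, and the source may have more. Where it says the series, first, only, none or still open, it means among the compounds named here.

Three chalcone-type amides have numbers in a functional assay on the whole organism (strain albino) for inhibition, with Rattus norvegicus as the target, read by paw edema, with stated times of 30 min and 4 h, at a dose of 100 mg/kg by the oral route (a higher number here means more inhibition at the dose given (going by the name of the read-out), a lower number less inhibition), so far. Compound 1 `COc1ccc(/C=C/C(=O)c2ccc(NC(=O)C(C)Br)cc2)cc1` gives 38%. Compound 2 `CC(Br)C(=O)Nc1ccc(C(=O)/C=C/c2ccco2)cc1` gives 36%. Compound 3 `COc1ccc(/C=C/C(=O)c2ccc(NC(=O)C(C)O[N+](=O)[O-])cc2)cc1` gives 43%, the highest of the three, though all three lie within the scatter of one another.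

The change furan-2-yl in place of 4-methoxyphenyl on a double-bonded chain carbon bound to a double-bonded chain carbon made a step of a number 2 percentage points lower from compound 1 to compound 2 (within the scatter). The cores of compound 1 and compound 3 differ by nitrooxy in place of bromo on a saturated chain carbon bound to a carbonyl carbon and a saturated chain carbon, and that step read a number 5 percentage points higher from compound 1 to compound 3 (within the scatter).

Compound 4 `CC(O[N+](=O)[O-])C(=O)Nc1ccc(C(=O)/C=C/c2ccco2)cc1` is not yet measured. It differs from compound 3 by furan-2-yl in place of 4-methoxyphenyl on a double-bonded chain carbon bound to a double-bonded chain carbon, the same change as from compound 1 to compound 2. On the earlier step of a number 2 percentage points lower from compound 1 to compound 2 (within the scatter) the expected step is a number 2 percentage points lower from compound 3 to compound 4 (within the scatter). Compound 4 is therefore estimated at 41%, with a range from 31% to 51%.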

Compound 4, a percentage reported as inhibition, in the whole organism at one dose (the size of the read-out at that dose, not a potency): 49%
Compound 4: middle estimate off by 8 percentage points, on the low side, and the stated range covers the measured number.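

In this assay, furan-2-yl in place of 4-methoxyphenyl gives a number 6 percentage points higher from compound 3 to compound 4 (within the scatter), and the two readings of this change do not differ: the same change on two cores in this assay, a number 2 percentage points lower (within the scatter) from compound 1 to compound 2 and a number 6 percentage points higher (within the scatter) from compound 3 to compound 4, 8 percentage points apart, within the scatter of two such steps. Nitrooxy in place of bromo gives a number 13 percentage points higher from compound 2 to compound 4 (beyond the scatter), and this change also reads alike on both cores, although only this step lies beyond the scatter: the same change on two cores in this assay, a number 5 percentage points higher (within the scatter) from compound 1 to compound 3 and a number 13 percentage points higher (beyond the scatter) from compound 2 to compound 4, 8 percentage points apart, within the scatter of two such steps. Both changes therefore carry over between these cores as far as the pairs shown go, but two cores at a single dose do not show that either change would keep its size on another core.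

Still open, on these data alone, is how an amine or a carboxylic acid in place of nitrooxy would read. Also open, as far as these compounds go, is how thiophene or pyridine would read in place of furan-2-yl.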